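Cytotoxicity notes: bromo replacing dichlorophenyl at the aryl end

A few compounds are considered here, and "the series" means these few. Any claim that something is new, unique, unknown or untested is made for them only; others in the source may bear on it.

Compound 1 `CCOC(=O)CCCCCOc1cccc(CN(C(=O)c2ccc(-c3cccc(C(C)=O)c3)cc2)C(C)C)c1` and compound 2 `CCOC(=O)CCCCCOc1cccc(CN(C(=O)c2ccc(-c3ccc(Cl)c(Cl)c3)cc2)C(C)C)c1` share one core and differ only in the aryl group on the benzamide. In an ADME assay on Raji cells (Homo sapiens) for cytotoxicity, read by CellTiter-Glo and resazurin assay, with a stated time of 72 h (on this read-out lower numbers stand for an effect already at smaller amounts and higher numbers for an effect only at larger amounts of compound), compound 1 returns a limit, > 26000 nM. In this assay compound 2 also returns a limit, > 26000 nM. The step that the two limits leave unreadable from compound 1 to compound 2 is unreadable because of the limit of > 26000 nM in this assay, at which 2 of the 2 values shown sit.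

Compound 3 `CCOC(=O)CCCCCOc1cccc(CN(C(=O)c2ccc(Br)cc2)C(C)C)c1` follows from compound 2 by bromo in place of 3,4-dichlorophenyl on an aromatic carbon. For the measured compounds named here, no measured step bears directly on this exchange; the single measured step, from compound 1 to compound 2, concerned a different change and has no readable size. Compound 2 itself stands only as a limit. The expectation for compound 3 is therefore that this assay again shows no effect within its range, so no step beyond the scatter is expected, a step that the limit leaves unreadable from compound 2 to compound 3. Compound 3 is estimated at 30000 nM (10000 nM to 100000 nM), most likely reported again as a limit.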

Compound 3, half-maximal effective concentration: > 26000 nM
Compound 3: only a limit was reported; the forecaster's own chance of this, stated with the estimate: 85%; the middle value lies beyond the limit too.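

In this assay compound 3 also gives only a limit, > 26000 nM. For the compounds shown here, no step among compound 1, compound 2 and compound 3 can be read, because they share one limit: the limit of > 26000 nM in this assay, at which 3 of the 3 values shown sit. The compounds shown leave open whether bromo, 3,4-dichlorophenyl or 3-acetylphenyl differ at all in this assay.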